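The source may hold more compounds than are shown below. What is called first, only, known or untested is meant among the compounds shown, and "the series" means these compounds.

Compound 2, `COC1=C(C)C(=O)/C(=C(O)/C=C/c2ccc(OC)cc2)C(=O)C1(C)C`, shares its core with compound 1, `COC1=C(C)C(=O)/C(=C(O)/C=C/c2ccc(Br)cc2)C(=O)C1(C)C`, and compound 3, `COC1=C(C)C(=O)/C(=C(O)/C=C/c2c(C)cccc2C)C(=O)C1(C)C`; the three differ only in the aromatic group at the end of the side chain. In a functional assay on KB cells (Homo sapiens) for cytotoxicity (a lower number here means that less compound is needed, a higher number that more compound is needed for the effect), compound 2 gives 3.6 ug/mL. Compound 1 gives 1.7 ug/mL, and compound 3 gives 7.1 ug/mL. Among these three numbers compound 2 stands second highest: its nearest neighbour is compound 3, with a 2.0-fold higher number from compound 2 to compound 3 (0.29 log units; within the scatter), and its furthest is compound 1, with a 2.1-fold higher number from compound 1 to compound 2 (0.33 log units; beyond the scatter).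

Compound 4, `COC1=C(C)C(=O)/C(=C(O)/C=C/c2cccs2)C(=O)C1(C)C`, is not yet measured. It differs from compound 2 in one place: thiophen-2-yl in place of 4-methoxyphenyl on a double-bonded chain carbon bound to a double-bonded chain carbon.

The measured steps that bear on this change are those that also swap the aromatic group on the chain: a 2.1-fold higher number from compound 1 to compound 2 (0.33 log units; beyond the scatter), a 4.2-fold higher number from compound 1 to compound 3 (0.62 log units; beyond the scatter) and a 2.0-fold higher number from compound 2 to compound 3 (0.29 log units; within the scatter). All three are modest or within the scatter, so exchanging one aromatic group for another has shifted the numbers little within this small set. The change to compound 4 is of the same kind, though it exchanges the whole ring rather than a group on it, so a step of similar modest size is expected, in either direction, and most likely no more than a small one. Compound 4 is therefore estimated at 3 ug/mL, between 1.2 ug/mL and 8 ug/mL, which would mean a 1.2-fold lower number from compound 2 to compound 4 (0.08 log units; within the scatter).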

Compound 4, concentration for half-maximal effect: 5.5 ug/mL
Estimate against measurement, compound 4: 1.8-fold (0.26 log units) below, within the range that was stated.
By their numbers in this assay, from the lowest: compound 1; then compounds 2, 4 and 3 (each within the scatter of the next).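

Thiophen-2-yl, a five-membered aromatic ring with 1 hetero atom, takes the place of the six-membered carbon rings on the double-bonded chain carbon, and in this assay the result stays within the scatter of two earlier compounds (a 1.5-fold higher number from compound 2 to compound 4 (0.18 log units; within the scatter); a 1.3-fold lower number from compound 3 to compound 4 (0.11 log units; within the scatter)). This position therefore accepts a change of the ring itself, not only of the groups on it, and a smaller group of 5 heavy atoms in place of the 8 of 4-methoxyphenyl leaves the number within the scatter. Compound 1 alone stands apart, as its steps to all three others lie beyond the scatter, now including the new one (a 3.2-fold higher number from compound 1 to compound 4 (0.51 log units; beyond the scatter)), but nothing measured here explains why the 4-bromophenyl group differs from the others.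

Every group shown is an aromatic ring, so it remains open whether a saturated ring such as cyclohexyl, or a plain alkyl chain, would fit this place on the chain. Going by these compounds, it is also open how a ring carrying an amine or a carboxylic acid would compare, and whether a bromo group on the thiophene ring would bring the number closer to that of compound 1.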